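From Trifluoromethyl to Carboxymethyl on an Acrylamide Chain

The source may report more compounds than this note shows. Statements on the series, on what has been measured and on what is new or still open speak of the compounds shown alone.

In an ADME assay for pharmacokinetics, read by LC-MS, in phosphate buffer, with a stated time of 120 min, at pH 7.4, tested at 1 uM, in the presence of a further agent that is not named here (on this read-out lower numbers stand for a shorter-lived compound and higher numbers for a longer-lived compound), compound 2 `O=C(/C=C/C(F)(F)F)Nc1ccccc1` gives 0.267 h. Among the three measured compounds, compound 2 stands as the only one with a plain number. Compound 1 `C=C(CO)C(=O)Nc1ccccc1` gives a reading that is only a limit of the assay, > 8.53 h. Compound 3 `C=C(F)C(=O)Nc1ccccc1` likewise gives only a limit, > 8.53 h. Among the compounds with values here, the single step between measured compounds, a step that the two limits leave unreadable from compound 1 to compound 3, cannot be sized because of the limit of > 8.53 h in this assay, at which 2 of the 3 values shown sit. Compound 4 `O=C(O)C/C=C/C(=O)Nc1ccccc1` differs from compound 2 by carboxymethyl in place of trifluoromethyl on a double-bonded chain carbon bound to a double-bonded chain carbon. Within the data shown here, no measured step touches this change, so the expectation rests on the one number for compound 2 alone. Compound 4 is expected to read 3 h, within 0.6 h to 8.53 h. The estimated step is an 11-fold higher number from compound 2 to compound 4 (1.05 log units; beyond the scatter), toward a longer-lived compound, with wide uncertainty.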

Compound 4, half-life: > 8.53 h
Compound 4 gave a limit, no number; the forecaster's own chance of this, stated with the estimate: 35%; middle value at least 2.8-fold (0.45 log units) from the limit.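

At this place on the chain, on a double-bonded chain carbon bound to a double-bonded chain carbon, carboxymethyl in place of trifluoromethyl gives an at least 31-fold higher number from compound 2 to compound 4 (1.50 log units; beyond the scatter) in this assay. Within the data shown here, this is the first step in the set that can be read, and it shows that this single change is enough to move the short-lived compound 2 to the top of the scale. Compound 4 gives only a limit of the assay, > 8.53 h.

Going by these compounds, how much longer-lived compound 4 really is stays open, because its reading stops at that limit: the limit of > 8.53 h in this assay, at which 3 of the 4 values shown sit. Whether an amine or a nitrile at this place would also bring such a large step remains unknown.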